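This account rests on a few compounds, and the source may have more. Where it says the series, first, only, none or still open, it means among the compounds named here.

Compound 1 `O=C1/C(=C/c2ccc(Br)cc2)Cc2ccccc21` is the weakest point of entry: in a functional assay on P388 cells (Mus musculus) for inhibition (a lower number here means a stronger inhibitor, a higher number a weaker inhibitor), compound 1 returns only a limit, > 50000 nM, a value that is one of those sitting at the limit of > 50000 nM in this assay, at which 1 of the 3 values shown sits. Compound 2 `Cc1ccc(/C=C2\Cc3ccccc3C2=O)cc1`, in this assay, gives 38600 nM. Among the measured compounds shown here, the only step counted between measured compounds, an at least 1.2-fold lower number from compound 1 to compound 2 (0.11 log units; that floor lies within the scatter), is methyl in place of bromo on an aromatic carbon; its size is a floor and cannot be read more closely, because compound 1 stands at the limit of > 50000 nM in this assay, at which 1 of the 3 values shown sits. Compound 3 `O=C1CCCCC/C1=C\c1cccc(Br)c1` gives 24100 nM in this assay; the difference between its core and that of compound 1 is not broken down here. Compound 4 `Cc1cccc(/C=C2\CCCCCC2=O)c1` is not yet measured; it differs from compound 3 by methyl in place of bromo on an aromatic carbon. The two changes are the same kind of change, not the same: in compound 2 the methyl sits para to a large group, in compound 4 meta to a group of 9 heavy atoms. With only a floor within the scatter to go on, the expected step of a 1.3-fold lower number from compound 3 to compound 4 (0.13 log units; within the scatter) is small, and compound 4 is expected near 18000 nM, between 7000 nM and 45000 nM.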

Compound 4, half-maximal inhibitory concentration: 29800 nM
Compound 4: the middle estimate sits 1.7-fold (0.22 log units) below what was measured, within the range that was stated.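

In this assay, methyl in place of bromo on the aromatic carbon gives a 1.2-fold higher number from compound 3 to compound 4 (0.09 log units; within the scatter) and so has no effect on this core that can be told from the usual spread of repeated measurements. Compound 1 gives > 50000 nM, which is a limit and not a number. What the step on the core of compound 3 shows is therefore narrow: it gives no sign of a strong effect of this change there, but it does not show that the change carries from one core to the other unaltered, nor that it behaves differently: the same change on two cores in this assay, an at least 1.2-fold lower number (0.11 log units; that floor lies within the scatter) from compound 1 to compound 2 and a 1.2-fold higher number (0.09 log units; within the scatter) from compound 3 to compound 4; the limit leaves it open whether they differ.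

The compounds shown leave open whether any group on the aromatic ring other than bromo or methyl, such as an amine, a carboxylic acid or a longer chain, would move the number beyond the scatter on either core. They also leave open what replacing the carbonyl of the shared enone-bearing part with an amide would do in this assay.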